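The source may hold more compounds than are shown below. What is called first, only, known or untested is meant among the compounds shown, and "the series" means these compounds.

Compound 1 `Cc1nc(N2CCC(O)CC2)nc2ccc(NC(=O)/C=C/c3ccc(Cl)cc3)cc12` is the starting point. Among the compounds with values here, in a functional assay on CHO-K1 cells for antagonist activity at melanin-concentrating hormone receptor 1 (Homo sapiens), read by inositol phosphate accumulation, with stated times of 10 min and 45 min (on this read-out higher numbers stand for weaker inhibition and lower numbers for stronger inhibition), compound 1 gives 73 nM, the second highest of the three numbers measured so far. In this assay compound 2 `Cc1nc(N2CCC(N3CCCC3=O)CC2)nc2ccc(NC(=O)/C=C/c3ccc(Cl)cc3)cc12` gives 20 nM, reached by a 3.7-fold lower number from compound 1 to compound 2 (0.56 log units; beyond the scatter). Compound 3 `C/C(=C\C(=O)Nc1ccc2nc(N3CCC(O)CC3)nc(C)c2c1)c1ccc(Cl)cc1` gives 227 nM, reached by a 3.1-fold higher number from compound 1 to compound 3 (0.49 log units; beyond the scatter). Compound 4 `Cc1nc(N(C)C2CCCC2)nc2ccc(NC(=O)/C=C/c3ccc(Cl)cc3)cc12` has not been measured; it differs from compound 1 by cyclopentyl(methyl)amino in place of 4-hydroxypiperidin-1-yl on an aromatic carbon. Within the data shown here, only the step from compound 1 to compound 2 touches this part of the shared core, and it exchanged the hydroxy while keeping the ring, so it bears on the new change only loosely. A modest step is therefore expected, with no confident direction. For compound 4 the expected value is 100 nM, with a range from 30 nM to 350 nM. This estimate corresponds to an expected step of a 1.4-fold higher number from compound 1 to compound 4 (0.14 log units; within the scatter).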

Compound 4, half-maximal inhibitory concentration: 57 nM
The estimate for compound 4 lay 1.8-fold (0.24 log units) above the measured number, within the range that was stated.
By their numbers in this assay, from the lowest: compound 2; then compounds 4 and 1 (each within the scatter of the next); then compound 3.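

With a 1.3-fold lower number from compound 1 to compound 4 (0.11 log units; within the scatter), this position tolerates replacing 4-hydroxypiperidin-1-yl, with its hydrogen-bond donor and six-membered ring containing oxygen and nitrogen, by cyclopentyl(methyl)amino, which has no donor and a five-membered ring of carbon only. In compound 1, therefore, neither the hydroxy nor the six-membered ring is needed to keep the number in this assay at this level. Nothing measured here explains why so large a change in structure leaves the number within the scatter. Still open, from the compounds shown here alone, is how dimethylamino or piperazin-1-yl would behave here, and whether cyclopentyl(methyl)amino would give a similar result alongside the 2-(4-chlorophenyl)prop-1-en-1-yl group of compound 3.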